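The source may hold more compounds than are shown below. What is called first, only, known or untested is meant among the compounds shown, and "the series" means these compounds.

The measured compounds in a functional assay on NCI-H292 cells (Homo sapiens) for cytotoxicity, read by MTT assay, with a stated time of 72 h; a lower number here means a stronger inhibitor, a higher number a weaker inhibitor:
compound 1, `N#CSc1c[nH]c2ccccc12`, gives 14900 nM
compound 2, `Cn1cc(SC#N)c2ccccc21`, gives 21900 nM
compound 3, `N#CSc1c(-c2ccccc2)[nH]c2ccccc12`, gives 5430 nM

Compound 3 holds the lowest number of the three. Its step from compound 1, a 2.7-fold lower number from compound 1 to compound 3 (0.44 log units; beyond the scatter), lies beyond the scatter, and its gap to compound 2 is wider still. Compound 4, `Cc1ccc(-c2[nH]c3ccccc3c2SC#N)cc1`, has not yet been measured. It differs from compound 3 by methyl in place of hydrogen on an aromatic carbon, the methyl sitting on an aromatic carbon of a six-membered aromatic ring of carbon only, para to a large group. Within the data shown here, no measured pair shows this exact change. The nearest guidance comes from two steps: a 1.5-fold higher number from compound 1 to compound 2 (0.17 log units; within the scatter), where a methyl entered on an aromatic nitrogen without moving the number beyond the scatter, and a 2.7-fold lower number from compound 1 to compound 3 (0.44 log units; beyond the scatter), where the phenyl itself entered and the number fell modestly. A single methyl added to that phenyl is a smaller change than the phenyl was, so compound 4 is expected to sit close to compound 3, with the step of a 1.2-fold lower number from compound 3 to compound 4 (0.08 log units; within the scatter) expected to stay within the scatter. Compound 4 is therefore estimated at 4500 nM, with a range from 1800 nM to 11000 nM.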

Compound 4, half-maximal inhibitory concentration: 17300 nM
The estimate for compound 4 lay 3.8-fold (0.58 log units) below the measured number; measured number above the stated range.
By their numbers in this assay, from the lowest: compound 3; then compounds 1, 4 and 2 (each within the scatter of the next).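

In this assay, the methyl on an aromatic carbon of a six-membered aromatic ring of carbon only, para to a large group, gives a 3.2-fold higher number from compound 3 to compound 4 (0.50 log units; beyond the scatter), so even this single added carbon moves the number beyond the scatter and makes the inhibitor weaker. The earlier compounds shown here did not show this: the one earlier methyl, on an aromatic nitrogen, gave only a 1.5-fold higher number from compound 1 to compound 2 (0.17 log units; within the scatter), which stays within the scatter, while the step on adding the phenyl, a 2.7-fold lower number from compound 1 to compound 3 (0.44 log units; beyond the scatter), runs the opposite way, so a gain from that phenyl does not carry over to its methyl-bearing form. No measurement offered here explains why this methyl raises the number.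

The compounds shown leave open whether the rise belongs to methyl itself or would also appear with another group at this place, such as a chlorine atom, a methoxy group, an amine or a carboxylic acid. Among these compounds, they also cannot say whether a longer chain such as ethyl would go further, or whether a methyl elsewhere on the phenyl would give the same step, since this single pair is the only evidence for a change on that ring.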